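Amide tail variation on an aryl sulfonate series

This account rests on a few compounds, and the source may have more. Where it says the series, first, only, none or still open, it means among the compounds named here.

Measured compounds in a functional assay on HT-1080 cells (Homo sapiens) for antiproliferative activity, read by sulforhodamine B assay, with a stated time of 48 h; a higher number here means a weaker inhibitor, a lower number a stronger inhibitor:
compound 1 `CCCC(=O)Nc1ccc(S(=O)(=O)Oc2ccccc2I)cc1` gives 2000 nM
compound 2 `O=C(CCl)Nc1ccc(S(=O)(=O)Oc2ccccc2I)cc1` gives 600 nM
compound 3 `O=C(CCCCl)Nc1ccc(S(=O)(=O)Oc2ccccc2I)cc1` gives 12000 nM

Compound 3 carries the highest number of the three: the step from compound 1 reads a 6.0-fold higher number from compound 1 to compound 3 (0.78 log units; beyond the scatter), and from compound 2 it reads a 20-fold higher number from compound 2 to compound 3 (1.30 log units; beyond the scatter). The remaining measured step is a 3.3-fold lower number from compound 1 to compound 2 (0.52 log units; beyond the scatter).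

Compound 4 `O=C(NCC1CCCC1)Nc1ccc(S(=O)(=O)Oc2ccccc2I)cc1` differs from compound 3 by (cyclopentylmethyl)amino in place of 3-chloropropyl on a carbonyl carbon, so the carbonyl becomes part of a carbamoyl rather than an acyl group. None of the three measured steps touches this kind of change; all of them concern a chloro on the saturated chain, and they range from modest to large in size. They show only that the tail on the carbonyl carbon moves the number well beyond the scatter in either direction.

Among the compounds with values here, with no direct precedent, the number for compound 4 is expected to fall back toward the range of compound 1 and compound 2 rather than stay at that of compound 3, giving an estimated step of a 4.0-fold lower number from compound 3 to compound 4 (0.60 log units; beyond the scatter). Compound 4 is therefore estimated at 3000 nM, with a wide range from 500 nM to 20000 nM.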

Compound 4, half-maximal inhibitory concentration: 6100 nM
Estimate against measurement, compound 4: 2.0-fold (0.31 log units) below; measured number inside the range.
By their numbers in this assay, from the lowest: compound 2; then compound 1; then compounds 4 and 3 (each within the scatter of the next).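

In this assay, the change from (3-chloropropyl)carbonyl to (cyclopentylmethyl)carbamoyl on the shared core gives a 2.0-fold lower number from compound 3 to compound 4 (0.29 log units; within the scatter) and so stays within the scatter, even though the incoming group brings a five-membered ring and a hydrogen-bond donor. Against the two other tails, the same group gives a 10-fold higher number from compound 2 to compound 4 (1.01 log units; beyond the scatter) for chloromethyl and a 3.1-fold higher number from compound 1 to compound 4 (0.48 log units; beyond the scatter) for propyl, so at this position the carbamoyl tail sits with the 3-chloropropyl tail and apart from those two. No measurement shown offers a reason for these steps.

Still open, going by these compounds, is how the amino nitrogen and the cyclopentyl ring each contribute, which a propylamino or a cyclopentylmethyl group on the same carbonyl carbon would separate. Also open, on these data alone, is how a bromomethyl tail or a carboxylic acid at the chain end would read here.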